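A few compounds are considered here, and "the series" means these few. Any claim that something is new, unique, unknown or untested is made for them only; others in the source may bear on it.

Among the compounds with values here, in a physicochemical assay for acid dissociation, compound 2 (`CC(C)Oc1noc2c1CNCC2`) gives 7.5 and stands within the scatter of compound 1 (`C/C=C/COc1noc2c1CNCC2`), which gives 7.7 as the only other number so far. Compound 3 (`C=CCOc1noc2c1CNCC2`) has not yet been measured. Its difference from compound 2 is allyl in place of isopropyl on an oxygen on an aromatic ring (in words, allyl in place of isopropyl on an oxygen on an aromatic ring). Within the data shown here, the one measured step at this oxygen is the exchange of but-2-en-1-yl for isopropyl (a number 0.20 log units lower from compound 1 to compound 2 (within the scatter)) and it is small. Among the measured compounds shown here, with only that step to go on, no step beyond the scatter is expected in this assay for the allyl group, although a single pair is thin support. With compound 1 at 7.7 and compound 2 at 7.5 as the only anchors, the estimate is placed midway between these two values. The estimated step is a number 0.10 log units higher from compound 2 to compound 3 (within the scatter) and no direction is claimed for it. For compound 3 the expected value is 7.6 with an estimated range from 7.3 to 7.9 in this series.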

Compound 3, acid dissociation constant: 7.5
For compound 3 the middle estimate is 0.10 log units above the measured one, within the range that was stated.
By their numbers in this assay, from the lowest: compounds 2, 3 and 1 (each within the scatter of the next).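

In this assay, the exchange of isopropyl for allyl on an oxygen on an aromatic ring gives no change at the digits printed from compound 2 to compound 3 (within the scatter), and the exchange of prop-1-en-1-yl for vinyl on a saturated chain carbon bound to that oxygen gives a number 0.20 log units lower from compound 1 to compound 3 (within the scatter). The series previously offered a single exchange at this oxygen; now all three pairs among isopropyl, allyl and but-2-en-1-yl lie within the scatter, so neither the double bond outside aromatic rings, which allyl carries and isopropyl does not, nor the difference between the vinyl and prop-1-en-1-yl ends goes with a step beyond the scatter in these compounds. No available evidence accounts for this closeness of the numbers.

From the compounds shown here alone, it remains open whether the same holds for a benzyl group, a longer chain, or a chain carrying an amine or a carboxylic acid on this oxygen. The compounds shown also leave open whether any change elsewhere on the shared core would give a step beyond the scatter in this assay.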